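A few compounds are considered here, and "the series" means these few. Any claim that something is new, unique, unknown or untested is made for them only; others in the source may bear on it.

Two compounds of the series have numbers in an assay on isolated protein for inhibition of RAC-alpha serine/threonine-protein kinase (Homo sapiens), tested at 30 uM; on this read-out higher numbers stand for more inhibition at the one concentration tested (going by the name of the read-out) and lower numbers for less inhibition. Compound 1 `Cn1cnc2c(SCc3ccc(F)cc3)ncnc21` gives 11% in this assay. Compound 2 `Nc1ncnc2c1ncn2Cc1ccc(F)cc1` gives 0% in this assay, the lowest of the two numbers, with compound 1 standing higher by a gap beyond the scatter. Compound 3 `Fc1ccc(Cn2cnc3c(Sc4ccc(F)cc4)ncnc32)cc1` has not been measured. It differs from compound 2 in one place: (4-fluorophenyl)sulfanyl in place of amino on an aromatic carbon. For the measured compounds named here, no measured pair shows this change, so the data give no step to lean on; a small rise is expected, and the step estimated in this assay is a number 10 percentage points higher from compound 2 to compound 3 (within the scatter). Compound 3 is expected to give about 10% in this assay, within 0% to 25%.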

Compound 3, a percentage reported as inhibition, at one concentration (the size of the read-out at that concentration, not a potency): 0%
Beside the measured number, compound 3's estimate is 10 percentage points above it; low and high end bracket the measured number.
By their numbers in this assay, from the lowest: compounds 2 and 3 (each within the scatter of the next); then compound 1.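

In this assay, (4-fluorophenyl)sulfanyl in place of amino on this aromatic carbon gives no change at the digits printed from compound 2 to compound 3 (within the scatter), so the added aromatic ring and sulfur bring no readable inhibition at this position. Compound 2 gives 0% in this read-out, so any loss from the change could not be seen from this starting point. No evidence on hand bears on why the number stays put. Still open, as far as these compounds go, is whether another group on this carbon, such as a morpholine or a carboxylic acid, would lift the number above the scatter.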